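The source may hold more compounds than are shown below. What is called first, only, known or untested is meant among the compounds shown, and "the series" means these compounds.

In a functional assay on M21 cells (Homo sapiens) for antiproliferative activity, read by sulforhodamine B assay, with a stated time of 48 h (on this read-out higher numbers stand for weaker inhibition and lower numbers for stronger inhibition), three compounds have been measured:

Compound 1, `CC(=O)Nc1cccc(S(=O)(=O)Oc2ccccc2C(C)C)c1`: 31000 nM
Compound 2, `CCC(=O)Nc1cccc(S(=O)(=O)Oc2ccccc2C(C)C)c1`: 25000 nM
Compound 3, `CC(=O)Nc1ccc(S(=O)(=O)Oc2ccccc2C(C)C)cc1`: 21000 nM

Compound 3 gives the lowest of the three numbers, but its separation from compound 2 and from compound 1 lies within the scatter, so the three compounds cannot be told apart on these data. Compound 4, `CC(C)c1ccccc1OS(=O)(=O)c1ccc(NC(=O)CCCl)cc1`, has not yet been measured. It differs from compound 3 by chloromethyl in place of hydrogen on a saturated chain carbon bound to a carbonyl carbon. Among the measured compounds shown here, only one measured step touches this kind of change: a 1.2-fold lower number from compound 1 to compound 2 (0.09 log units; within the scatter), which also lengthens the chain on the saturated carbon bound to the carbonyl carbon and moved the number by less than the scatter. Compound 4 extends the same chain by a larger group, so a step of roughly the same modest size is anticipated, with no firm direction beyond the scatter. The expected step is a 1.2-fold lower number from compound 3 to compound 4 (0.07 log units; within the scatter). Compound 4 is therefore estimated at 18000 nM, with a range from 7000 nM to 45000 nM.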

Compound 4, half-maximal inhibitory concentration: 14000 nM
For compound 4 the middle estimate is 1.3-fold (0.11 log units) above the measured one; the range from low to high includes it.
By their numbers in this assay, from the lowest: compounds 4, 3, 2 and 1 (each within the scatter of the next, the first and the last beyond it).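

In this assay the exchange of acetamido for ((2-chloroethyl)carbonyl)amino gives a 1.5-fold lower number from compound 3 to compound 4 (0.18 log units; within the scatter) and so leaves compound 3 and compound 4 indistinguishable on these data. The earlier compounds shown here showed only methyl entering on a saturated chain carbon bound to a carbonyl carbon, and only in the pair of compound 1 and compound 2. Compound 4 adds that chloromethyl, a group of 2 heavy atoms that brings chlorine into the chain, can enter at this place on the core of compound 3 without a step beyond the scatter, although no measurement given here bears on what lies behind this result.

Still open, from the compounds shown here alone, is whether a longer chain at this place would give a step beyond the scatter. Going by these compounds, it is equally open whether an amine or a carboxylic acid in place of the chlorine would do so.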